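Swapping the amide-side ring in a p300 inhibitor series

This account rests on a few compounds, and the source may have more. Where it says the series, first, only, none or still open, it means among the compounds named here.

Compound 2 `O=C1Cc2cc(NC(=O)[C@H]3CCCN3C(=O)C3(c4cccc(Cl)c4)CCCC3)ccc2N1` stands second highest of three numbers in an assay on isolated protein for inhibition of histone acetyltransferase p300 (Homo sapiens), with a stated time of 60 min (a lower number here means a stronger inhibitor, a higher number a weaker inhibitor), where it gives 0.794 nM. Compound 1 `COc1ccc(C2(C(=O)N3CCC[C@@H]3C(=O)Nc3ccc4[nH]ncc4n3)CCC2)cc1` gives 0.251 nM in this assay, a lower number that lies beyond the scatter, while compound 3 `COc1ccc(NC(=O)[C@H]2CCCN2C(=O)C2(c3ccc(Cl)cc3)CCC2)cc1` gives 10 nM, a higher number also beyond the scatter. Compound 4 `CNC(=O)c1ccc(NC(=O)[C@H]2CCCN2C(=O)C2(c3cccc(Cl)c3)CCCC2)cc1` differs from compound 2 in one place: a group of 10 heavy atoms (8 carbon, 1 nitrogen, 1 oxygen; one six-membered aromatic ring of carbon only) in place of a group of 10 heavy atoms (8 carbon, 1 nitrogen, 1 oxygen; one five-membered non-aromatic ring with 1 hetero atom, one six-membered aromatic ring of carbon only), on an amide-type nitrogen. Going by the values given here, no measured pair shows this exact change, so the step is uncertain. Among the compounds with values here, compound 4 is expected to lose some potency, since the one compound carrying a plain substituted phenyl on that nitrogen, compound 3, gave 10 nM. The estimated step from compound 2 to compound 4 is a 3.8-fold higher number from compound 2 to compound 4 (0.58 log units; beyond the scatter), a modest weakening. For compound 4 the expected value in this assay is 3 nM, ranging from 0.8 nM to 12 nM.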

Compound 4, half-maximal inhibitory concentration: 0.794 nM
Estimate against measurement, compound 4: 3.8-fold (0.58 log units) above; the measured number lies below the stated range.
By their numbers in this assay, from the lowest: compound 1; then compounds 2 and 4 (each within the scatter of the next); then compound 3.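

In this assay the change gives no change at the digits printed from compound 2 to compound 4 (within the scatter), so on this amide-type nitrogen a group with a single six-membered aromatic ring, 4-(methylcarbamoyl)phenyl, matches one that also carries a five-membered non-aromatic ring. Going by these compounds alone, in this pair, then, the five-membered ring is not needed to keep the number, which no earlier pair could test. No measurement here explains why the two groups match. Still open, on these data alone, is how much the methylcarbamoyl group itself contributes, for example against a carboxylic acid or an amine in its place. Whether the match holds on the other cores shown is also unknown.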